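1H-pyrazol-4-yl in place of cyclohexyl

The compounds below may be only part of what the source reports. "The series", "measured", "known", "first", "only" and "open" are said of these compounds alone.

Among the compounds with values here, in a physicochemical assay for lipophilicity, at pH 7.4 (on this read-out lower numbers stand for lower lipophilicity and higher numbers for higher lipophilicity), compound 1 `O=c1[nH]c(OC2CCCCC2)nc2cnccc12` gives 3.7, the highest of the three numbers so far. Compound 2 `O=c1[nH]c(Oc2cccc(O)c2)nc2cnccc12` gives 0.3, and compound 3 `O=c1[nH]c(Oc2ccc(Cl)c(O)c2)nc2cnccc12` gives 1.1; both lie well under compound 1. Compound 4 `O=c1[nH]c(Oc2cn[nH]c2)nc2cnccc12` is not yet measured. Its structure differs from that of compound 1 by 1H-pyrazol-4-yl in place of cyclohexyl on an oxygen on an aromatic ring.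

Within the data shown here, the only measured step, a number 0.80 log units higher from compound 2 to compound 3 (beyond the scatter), is a modest one for chloro in place of hydrogen on an aromatic carbon, so it bears on this change only loosely. Among the measured compounds shown here, no measured step covers the loss of cyclohexyl itself. Compound 4 has an aromatic ring on that oxygen, as does compound 2 at 0.3, so a value near that one is expected. The step expected is downward and large, well beyond the scatter: a number 3.60 log units lower from compound 1 to compound 4 (beyond the scatter). For compound 4 the estimated value is 0.1, with an expected range of -0.6 to 0.8.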

Compound 4, distribution coefficient: -0.6
For compound 4 the middle estimate is 0.70 log units above the measured one; low and high end bracket the measured number.
By their numbers in this assay, from the lowest: compound 4; then compound 2; then compound 3; then compound 1.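

In this assay, exchanging the group on this oxygen gives a number 4.30 log units lower from compound 1 to compound 4 (beyond the scatter), a large step, and the two compounds now mark the ends of the range shown. Compound 2 gives 0.3 and compound 4 gives -0.6, so among the aromatic groups on this oxygen, 1H-pyrazol-4-yl gives the lower printed number. The entering group brings a hydrogen-bond donor and a hydrogen-bond acceptor, and cyclohexyl has neither, but no measurement here accounts for the size of the step.

Open, from the compounds shown here alone, is where a 1-methylpyrazol-4-yl group or a piperidin-4-yl group on this oxygen would fall, which would help separate ring type from the donor count. Also open, going by these compounds, is whether chloro on the 1H-pyrazol-4-yl ring would repeat a number 0.80 log units higher from compound 2 to compound 3 (beyond the scatter).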